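Replacing 2-Chlorophenyl with 4-Bromophenyl on a Shared Core

The source may hold more compounds than are shown below. What is called first, only, known or untested is meant among the compounds shown, and "the series" means these compounds.

Measured so far:
- compound 1 `NC1=NC2(CCOCC2)N(OCCCOc2ccccc2Cl)C(N)=N1`: 660 nM
- compound 2 `NC1=NC2(CCSCC2)N(OCCCOc2ccccc2Cl)C(N)=N1`: 390 nM

Of the compounds shown here, two built on the same core have been tested in a functional assay on HL-60 cells (Homo sapiens) for antiproliferative activity, read by MTT assay, with a stated time of 72 h; on this read-out lower numbers stand for stronger inhibition and higher numbers for weaker inhibition. Compound 1 gives 660 nM in this assay, and compound 2 gives 390 nM. Compound 1 has the higher of the two numbers, but its nearest neighbour, compound 2, lies within the usual scatter of such measurements, so the two cannot be ranked against each other. Compound 1 and compound 2 differ in the ring within the core, not in the side chain, so their pair says nothing about the change that leads to compound 3.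

Compound 3 `NC1=NC2(CCOCC2)N(OCCCOc2ccc(Br)cc2)C(N)=N1` has not yet been measured. Compared with compound 1, the change is: 4-bromophenyl in place of 2-chlorophenyl on an oxygen on a saturated carbon. Going by the values given here, no measured pair shows this kind of change, so there is no step in this assay to lean on. With nothing to support a shift in either direction, the step of a 1.1-fold higher number from compound 1 to compound 3 (0.03 log units; within the scatter) is expected to stay within the scatter. Compound 3 is therefore estimated at about 700 nM in this assay, with a range from 250 nM to 2000 nM.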

Compound 3, half-maximal inhibitory concentration: 310 nM
The estimate for compound 3 lay 2.3-fold (0.35 log units) above the measured number, and the stated range covers the measured number.
By their numbers in this assay, from the lowest: compounds 3, 2 and 1 (each within the scatter of the next, the first and the last beyond it).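

In this assay putting 4-bromophenyl in place of 2-chlorophenyl on an oxygen on a saturated carbon gives a 2.1-fold lower number from compound 1 to compound 3 (0.33 log units; beyond the scatter) and so shows that the number responds to a change at this position, which the earlier pair of compounds left untouched. The step is modest, and the two groups have the same count of heavy atoms, the same six-membered aromatic ring of carbon only, and no hydrogen-bond donors or acceptors, so a swap that leaves these counts unchanged is still enough to move the number beyond the scatter. Both the halogen and its place on the ring differ in this swap, and nothing measured here explains the shift.

As far as these compounds go, it remains open whether the lower number goes with bromine or with the 4 position, and 2-bromophenyl and 4-chlorophenyl on the same core would separate those two possibilities. Also open, from the compounds shown here alone, are whether 4-bromophenyl would give a similar step on the core of compound 2, and how a phenyl ring carrying an amine or a carboxylic acid, or a longer chain, would behave.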